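From Chloro to Amino on a Shared Core

The source may hold more compounds than are shown below. What is called first, only, known or untested is meant among the compounds shown, and "the series" means these compounds.

For the measured compounds named here, compound 1 `O=c1oc2ccc(Cl)cc2n1Cc1cccc(F)c1` stands as the stronger of the two compounds measured so far in an assay on HeLa cells for inhibition of Indoleamine 2,3-dioxygenase 1 (Homo sapiens), with a stated time of 24 h (on this read-out higher numbers stand for weaker inhibition and lower numbers for stronger inhibition), where compound 1 gives 9750 nM. Compound 2 `O=c1oc2ccc([N+](=O)[O-])cc2n1Cc1ccc(Cl)cc1` differs from compound 1 in several places. In this assay compound 2 gives 99400 nM, a higher number that lies beyond the usual scatter. The change from compound 1 to compound 3 `Nc1ccc2oc(=O)n(Cc3cccc(F)c3)c2c1` puts (amino in place of chloro on an aromatic carbon). Going by the values given here, no pair of measured compounds differing in a single place exists here, so there is nothing directly comparable for the size of this step. Compound 2 carries a different group in place of the chloro of compound 1 together with a second change, and how much of its weaker number belongs to either change is not known. The expected step of a 1.5-fold higher number from compound 1 to compound 3 (0.19 log units; within the scatter) is small, leaning toward a higher number but possibly within the scatter. Compound 3 is estimated at 15000 nM, with a range from 4000 nM to 60000 nM.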

Compound 3, half-maximal inhibitory concentration: > 100000 nM
Compound 3 was reported as a limit; the forecaster's own chance of this, stated with the estimate: 10%; middle value at least 6.6-fold (0.82 log units) from the limit.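

Amino in place of chloro on this aromatic carbon gives the first comparison on the shared core that rests on a single change, and in this assay that change produces an at least 10-fold higher number from compound 1 to compound 3 (1.01 log units; beyond the scatter). Compound 2 differs from compound 1 in several places and could not show what this position alone contributes, whereas here the loss of inhibition belongs to this one exchange. Compound 3 gives > 100000 nM, which is a limit of the assay and not a number, and this step therefore marks only the least size of the change: the limit of > 100000 nM in this assay, at which 1 of the 3 values shown sits.

Going by these compounds, whether the loss is particular to amino or extends to other groups on this carbon, such as methoxy, bromo or an acetamide, stays open. On these data alone, how far the value of compound 3 lies past its limit also remains unknown.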